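The compounds below may be only part of what the source reports. "The series", "measured", "known", "first", "only" and "open" are said of these compounds alone.

Measured so far in a functional assay on CHO cells for antagonist activity at sphingosine 1-phosphate receptor 2 (Homo sapiens), read by calcium flux; a higher number here means a weaker inhibitor, a lower number a stronger inhibitor:

compound 1 `CC(C(=O)O)c1nn(Cc2cn3cc(OCC4CC4)c(Cl)cc3n2)c2ccccc2c1=O` gives 6 nM
compound 2 `O=C(O)Cn1nc(Cn2cc3cc(OCC4CC4)c(Cl)cc3n2)c2ccccc2c1=O` gives 11 nM
compound 3 `CC(C)(C(=O)O)c1nn(Cc2cn3cc(OCC4CC4)c(Cl)cc3n2)c2ccccc2c1=O` gives 7.7 nM

Compound 1 and compound 2 carry different cores; the difference between the two cores is not broken down here. Compounds 1, 2 and 3 all sit within the scatter of one another in this assay. Compound 3 arises from compound 1 by methyl in place of hydrogen on a saturated chain carbon bound to an aromatic carbon, a carbonyl carbon and a saturated chain carbon and that step reads a 1.3-fold higher number from compound 1 to compound 3 (0.11 log units; within the scatter).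

Compound 4 `C[C@H](C(=O)O)n1nc(Cn2cc3cc(OCC4CC4)c(Cl)cc3n2)c2ccccc2c1=O` is not yet measured. It arises from compound 2 by methyl in place of hydrogen on a saturated chain carbon bound to an aromatic nitrogen and a carbonyl carbon. Among the compounds with values here, this is the same kind of change as the one from compound 1 to compound 3, though the surroundings differ: there the carbon was bound to an aromatic carbon, a carbonyl carbon and a saturated chain carbon; here it is bound to an aromatic nitrogen and a carbonyl carbon. Given that a 1.3-fold higher number from compound 1 to compound 3 (0.11 log units; within the scatter) sat within the scatter, a step of about a 1.1-fold higher number from compound 2 to compound 4 (0.04 log units; within the scatter) is expected for compound 4, with the single defined stereocentre of compound 4 adding uncertainty. Compound 4 is thus estimated at 12 nM, between 5 nM and 30 nM.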

Compound 4, half-maximal inhibitory concentration in the sphingosine 1-phosphate receptor 2 assay: 3.2 nM
Estimate against measurement, compound 4: 3.8-fold (0.57 log units) above; the whole stated range lies above it.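

In the sphingosine 1-phosphate receptor 2 assay the change from carboxymethyl to 1-carboxyethyl reads a 3.4-fold lower number from compound 2 to compound 4 (0.54 log units; beyond the scatter), and the size of the step does not carry over unchanged from one core to the other: the same change on two cores in the sphingosine 1-phosphate receptor 2 assay, a 1.3-fold higher number (0.11 log units; within the scatter) from compound 1 to compound 3 and a 3.4-fold lower number (0.54 log units; beyond the scatter) from compound 2 to compound 4, 4.4-fold (0.64 log units) apart, beyond the scatter of two such steps With one pair on each core, this shows that the methyl step depends on the core here, but not which feature of the cores lies behind the gap, nor how the step would read on a third core. The same pair also differs in a physicochemical assay for solubility, measured as thermodynamic solubility, at pH 7.4 (on this read-out higher numbers stand for higher solubility and lower numbers for lower solubility), where compound 2 gives 334 ug/mL and compound 4 gives 958 ug/mL: the measured solubility of compound 2, 334 ug/mL, and of compound 4, 958 ug/mL, a 2.9-fold higher number (0.46 log units; beyond the scatter)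

Open, going by these compounds, is whether an ethyl group or a longer chain in place of the methyl would read like compound 4 on this core. Also open, on these data alone, is how the mirror-image form of compound 4, or a primary amide in place of the carboxylic acid, would read in either assay.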